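Halogen Swap on the Sulfonyl Phenyl Ring

The source may report more compounds than this note shows. Statements on the series, on what has been measured and on what is new or still open speak of the compounds shown alone.

Compound 1 `CC1CCN(c2c(S(=O)(=O)c3cccc(C#N)c3)cnc3ccc(F)cc23)CC1`: 93%
Compound 2 `CC1CCN(c2c(S(=O)(=O)c3cc(Cl)cc(Cl)c3)cnc3ccc(F)cc23)CC1`: 69%

In an assay on isolated protein for displacement of a labelled ligand from metabotropic glutamate receptor 5 (Homo sapiens), with a stated time of 60 min, tested at 1 uM (on this read-out higher numbers stand for more inhibition at the one concentration tested (going by the name of the read-out) and lower numbers for less inhibition), compound 1 gives 93%, while compound 2 gives 69%. Compound 2 thus stands lowest of the two numbers measured, and the step of a number 24 percentage points lower from compound 1 to compound 2 (beyond the scatter) lies beyond the scatter, so the phenyl ring on the sulfonyl sulfur clearly matters for this read-out.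

Compound 3 `CC1CCN(c2c(S(=O)(=O)c3ccc(F)c(Cl)c3)cnc3ccc(F)cc23)CC1` is not yet measured. Its change from compound 2 is 3-chloro-4-fluorophenyl in place of 3,5-dichlorophenyl on a sulfonyl sulfur. Among the compounds with values here, the only measured step, a number 24 percentage points lower from compound 1 to compound 2 (beyond the scatter), concerns a nitrile ring giving way to a dichloro ring and so does not match a swap between two halogenated rings; it shows only that this part of the molecule can move the number modestly. Within the data shown here, with no matching step, the expected change is a number 6 percentage points higher from compound 2 to compound 3 (within the scatter), a shift not clearly beyond the scatter in either direction. Compound 3 is therefore estimated to give about 75%, with a likely range from 50% to 95%.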

Compound 3, a percentage reported as inhibition, at one concentration (the size of the read-out at that concentration, not a potency): 95%
The estimate for compound 3 lay 20 percentage points below the measured number; the range from low to high includes it.
By their numbers in this assay, from the lowest: compound 2; then compounds 1 and 3 (each within the scatter of the next).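

In this assay, the step of a number 26 percentage points higher from compound 2 to compound 3 (beyond the scatter) shows that a halogenated ring on the sulfonyl sulfur does not by itself fix the number, since 3,5-dichlorophenyl and 3-chloro-4-fluorophenyl read far apart despite having the same count of heavy atoms. The step of a number 2 percentage points higher from compound 1 to compound 3 (within the scatter) stays within the scatter, so the drop seen with compound 2 is not shared by compound 3, and the 3-cyanophenyl ring and the 3-chloro-4-fluorophenyl ring cannot be told apart here. No evidence at hand accounts for the difference between the two halogenated rings.

Still open, as far as these compounds go, is whether the rise belongs to the added fluorine or to the lost second chlorine, which a plain 3-chlorophenyl or 4-fluorophenyl ring could help separate. Also open, from the compounds shown here alone, is how this position would respond to a ring carrying an amine or a carboxylic acid.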